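The source may report more compounds than this note shows. Statements on the series, on what has been measured and on what is new or still open speak of the compounds shown alone.

Among the measured compounds shown here, the three compounds measured so far share one core and differ only in the aromatic group on the piperazine nitrogen. Compound 1 `COc1ccccc1N1CCN(CCCCC(=O)c2ccccc2O)CC1` gives 16.4 nM in an assay on isolated protein for binding affinity to 5-hydroxytryptamine receptor 7 (Rattus norvegicus); on this read-out lower numbers stand for stronger inhibition and higher numbers for weaker inhibition. Compound 2 `O=C(CCCCCN1CCN(c2ccccn2)CC1)c1ccccc1O` gives 105 nM in this assay, and compound 3 `O=C(CCCCCN1CCN(c2ccccc2)CC1)c1ccccc1O` gives 43 nM. Compound 3 therefore holds the second highest of the three numbers: compound 2 sits nearest to it, compound 1 furthest. For the measured compounds named here, the one step that changes only this aromatic group is a 2.4-fold lower number from compound 2 to compound 3 (0.39 log units; beyond the scatter), so replacing a nitrogen-containing six-membered aromatic ring with a plain phenyl gave a modestly lower number.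

Compound 4 `O=C(CCCCCN1CCN(c2nc3ccccc3[nH]2)CC1)c1ccccc1O` reverses that kind of change: 1H-benzimidazol-2-yl in place of phenyl on an amine nitrogen in a ring. Going by the values given here, since the only comparable step, from a nitrogen-containing aromatic ring to phenyl, lowered the number, putting a nitrogen-containing aromatic system back in place of phenyl is expected to raise it by a similar modest amount, as a 2.8-fold higher number from compound 3 to compound 4 (0.45 log units; beyond the scatter). Compound 4 is thus estimated at 120 nM, with a likely range from 40 nM to 400 nM.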

Compound 4, inhibition constant: 682 nM
Compound 4: the middle estimate sits 5.7-fold (0.75 log units) below what was measured; measured number outside the range, above it.
By their numbers in this assay, from the lowest: compound 1; then compound 3; then compound 2; then compound 4.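

In this assay, the group on an amine nitrogen in a ring proves able to shift the number far more than the earlier pair showed: 1H-benzimidazol-2-yl in place of phenyl gives a 16-fold higher number from compound 3 to compound 4 (1.20 log units; beyond the scatter), well beyond the earlier 2.4-fold lower number from compound 2 to compound 3 (0.39 log units; beyond the scatter). The same group in place of pyridin-2-yl gives a 6.5-fold higher number from compound 2 to compound 4 (0.81 log units; beyond the scatter), so it carries a higher number than either single-ring group, and a ring nitrogen in the aromatic group does not alone set the size of the change. No measurement at hand explains this rise.

The new group brings a second ring, two nitrogen atoms and a hydrogen-bond donor all at once, and these compounds cannot tell which of these goes with the higher number. From the compounds shown here alone, whether naphthalen-2-yl, with two aromatic rings of carbon only, would give a similar number remains open.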